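Swapping Pyrrole for Imidazole: Expected Cytotoxicity Tolerance

A few compounds are considered here, and "the series" means these few. Any claim that something is new, unique, unknown or untested is made for them only; others in the source may bear on it.

Measured compounds:
Compound 1, `Cc1cc(-c2ccc(C=O)cc2)cn2c(CSCCc3ccccc3)cnc12`, gives 100 ug/mL in an ADME assay on HEL cells (Homo sapiens) for cytotoxicity, with a stated time of 3 days; a higher number here means that more compound is tolerated, a lower number that less compound is tolerated.
Compound 2, `Cc1cc(-n2cccc2)cn2c(CSCCc3ccccc3)cnc12`, reaches only the limit >= 4 ug/mL in this assay.

Compound 2 stands at the limit (the limit of >= 4 ug/mL in this assay, at which 1 of the 2 values shown sits), so only a bound is known for it, not a number. For the measured compounds named here, the single measured step, a step that the limit leaves unreadable from compound 1 to compound 2, is therefore unreadable because of the limit of >= 4 ug/mL in this assay, at which 1 of the 2 values shown sits.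

Compound 3, `Cc1cc(-n2ccnc2)cn2c(CSCCc3ccccc3)cnc12`, differs from compound 2 by 1H-imidazol-1-yl in place of 1H-pyrrol-1-yl on an aromatic carbon. No measured step covers a change of this kind, and the one step known is unreadable, so nothing shown points to a direction for the move from compound 2 to compound 3. With only the bound for compound 2 and the value of compound 1 as anchors, compound 3 is expected to give about 20 ug/mL, within a range from 4 ug/mL to 100 ug/mL. The step that the limit leaves unreadable from compound 2 to compound 3 that this estimate implies is itself only an expectation, and a limit report is quite possible.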

Compound 3, minimum cytotoxic concentration: 100 ug/mL
Estimate against measurement, compound 3: 5.0-fold (0.70 log units) below; the measured number falls inside the stated range.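

In this assay, compound 3 gives a real number rather than a limit, so the 1H-imidazol-1-yl group can be compared directly with the 4-formylphenyl group of compound 1, and the result is no change at the digits printed from compound 1 to compound 3 (within the scatter). On this aromatic carbon, then, a single five-membered aromatic ring with 2 hetero atoms and the 4-formylphenyl group read the same in these cells, at least for these two compounds. Both steps involving compound 2, including the change from 1H-pyrrol-1-yl to 1H-imidazol-1-yl, still cannot be read, because its value is only a limit: the limit of >= 4 ug/mL in this assay, at which 1 of the 3 values shown sits.

From the compounds shown here alone, it remains open whether compound 2 truly differs from compound 3 in this assay. Also open, going by these compounds, is how an amine, a carboxylic acid or a longer alkyl chain on this carbon would read in this assay.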